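Fluoro for Ethoxy on a Bis-Triazole Thiol Scaffold

The source may report more compounds than this note shows. Statements on the series, on what has been measured and on what is new or still open speak of the compounds shown alone.

Compound 2 `CCOc1ccc(-n2c(S)nnc2CSc2nnc(-c3ccccc3)n2-c2ccccc2)cc1` has no number in a functional assay on MDA-MB-231 cells (Homo sapiens) for inhibition, read by MTT assay, with a stated time of 48 h; a lower number here means a stronger inhibitor, a higher number a weaker inhibitor: its entry reads "not determined" (no result reported). Compound 1 `CC(C)n1c(S)nnc1Sc1nnc(-c2ccccc2)n1-c1ccccc1` likewise reports "not determined" (no result reported) in this assay . Among the measured compounds shown here, the only numeric anchor is compound 3 `Fc1ccc(-n2c(S)nnc2Sc2nnc(-c3ccccc3)n2-c2ccccc2)cc1`, which in this assay gives 29700 nM. Compound 4 `Fc1ccc(-n2c(S)nnc2CSc2nnc(-c3ccccc3)n2-c2ccccc2)cc1` arises from compound 2 through (fluoro in place of ethoxy on an aromatic carbon), fluoro in place of ethoxy on an aromatic carbon. For the measured compounds named here, with no measured step for this pair, no direction of change can be claimed for compound 4 beyond the scatter. Taking compound 3 as the closest measured relative, compound 4 is expected in this assay to fall near 30000 nM, within an estimated range from 8000 nM to 110000 nM.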

Compound 4, half-maximal inhibitory concentration: 26800 nM
Estimate against measurement, compound 4: 1.1-fold (0.05 log units) above; measured number inside the range.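

In this assay, among the compounds shown here, compound 2 has no single number, so no step to compound 4 can be read. The compounds shown leave open what the change from 4-ethoxyphenyl to 4-fluorophenyl does to inhibition. No evidence bears on this result.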